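Shortening the acid-bearing side chain on the shared core

The source may report more compounds than this note shows. Statements on the series, on what has been measured and on what is new or still open speak of the compounds shown alone.

Measured compounds:
compound 1 `COC(C(=O)O)c1nn(Cc2cn3cc(OCC4CC4)c(Cl)cc3n2)c2ccccc2c1=O` — 94 nM
compound 2 `CCC(C(=O)O)c1nn(Cc2cn3cc(OCC4CC4)c(Cl)cc3n2)c2ccccc2c1=O` — 5.6 nM

Both compounds were tested in a functional assay on HFL1 cells for antagonist activity at sphingosine 1-phosphate receptor 2 (Homo sapiens), read by ELISA, with a stated time of 24 h; a higher number here means a weaker inhibitor, a lower number a stronger inhibitor. Compound 2 gives the lower of the two numbers, and its nearest neighbour is compound 1, reached by a 17-fold lower number from compound 1 to compound 2 (1.22 log units; beyond the scatter). Compound 3 `C[C@H](C(=O)O)c1nn(Cc2cn3cc(OCC4CC4)c(Cl)cc3n2)c2ccccc2c1=O` is not yet measured. It differs from compound 2 in one place: 1-carboxyethyl in place of 1-carboxypropyl on an aromatic carbon. Within the data shown here, the only measured step concerns the same position, where ethyl replaced methoxy and gave a large drop in number; it does not directly show what removing one carbon from the ethyl does, and the defined stereocentre of compound 3 has no counterpart among the measured compounds. A step of modest size in either direction, or none beyond the scatter, is therefore expected. Compound 3 is estimated at 8 nM, within 2.5 nM to 30 nM, corresponding to an expected step of a 1.4-fold higher number from compound 2 to compound 3 (0.15 log units; within the scatter).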

Compound 3, half-maximal inhibitory concentration: 2.1 nM
Compound 3: the middle estimate sits 3.8-fold (0.58 log units) above what was measured; measured number below the stated range.
By their numbers in this assay, from the lowest: compound 3; then compound 2; then compound 1.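

In this assay, the side chain can lose a carbon without the number rising: 1-carboxyethyl in place of 1-carboxypropyl gives a 2.7-fold lower number from compound 2 to compound 3 (0.43 log units; beyond the scatter) and makes compound 3 the strongest inhibitor of the three. Measured against the methoxy-bearing chain, the same group gives a 45-fold lower number from compound 1 to compound 3 (1.65 log units; beyond the scatter) and this is the widest gap in the set. The change to 1-carboxyethyl also brings a defined stereocentre, so this step cannot separate the effect of the shorter chain from that of the stereocentre.

On these data alone, it remains open how the mirror-image form of compound 3 would compare. Also open, as far as these compounds go, is what carboxymethyl, with no branch on the chain, or a primary amide in place of the carboxylic acid would do at this position.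

Nothing available here explains the size of these steps.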